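The source may report more compounds than this note shows. Statements on the series, on what has been measured and on what is new or still open speak of the compounds shown alone.

Among the measured compounds shown here, compound 2 `Cc1occc1-c1nnc(SCC(=O)Nc2ccc(N(C)C)cc2)n1Cc1ccco1` is the one member of this pair with a number in a functional assay on CHO cells for antagonist activity at Orexin receptor type 2 (Homo sapiens), read by FLIPR and calcium flux; on this read-out lower numbers stand for stronger inhibition and higher numbers for weaker inhibition: compound 2 gives 158 nM. Compound 1 `Cc1cccc(C)c1NC(=O)CSc1nnc(-c2ccoc2C)n1Cc1ccco1` reaches only a limit; in this assay compound 1 gives > 15800 nM, which is a limit of the assay and not a number (the limit of > 15800 nM in this assay, at which 1 of the 2 values shown sits). For the measured compounds named here, the single measured step, an at least 100-fold lower number from compound 1 to compound 2 (2.00 log units; beyond the scatter), shows how strongly the group on the amide-type nitrogen can shift the read-out. Compound 3 `Cc1occc1-c1nnc(SCC(=O)NN2CCc3ccccc32)n1Cc1ccco1` alters that same position once more: 2,3-dihydro-1H-indol-1-yl in place of 4-(dimethylamino)phenyl on an amide-type nitrogen. Going by the values given here, no measured step covers this particular exchange; the only comparison at hand, an at least 100-fold lower number from compound 1 to compound 2 (2.00 log units; beyond the scatter), shows merely that a change here can move the number a long way. Compound 3 is therefore expected to lose rather than gain, with a step of a 32-fold higher number from compound 2 to compound 3 (1.50 log units; beyond the scatter) estimated. For compound 3 the estimate in this assay is 5000 nM, expected to fall between 800 nM and 30000 nM.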

Compound 3, inhibition constant: 1000 nM
The estimate for compound 3 lay 5.0-fold (0.70 log units) above the measured number; the measured number falls inside the stated range.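

In this assay, among the compounds shown here, compound 3 shows that 4-(dimethylamino)phenyl is not the only group on this amide-type nitrogen to give a measurable number: 2,3-dihydro-1H-indol-1-yl, with the same heavy-atom count, costs only a 6.3-fold higher number from compound 2 to compound 3 (0.80 log units; beyond the scatter). The same group still leaves an at least 15-fold lower number from compound 1 to compound 3 (1.19 log units; beyond the scatter), so the large difference seen earlier does not belong to the 4-(dimethylamino)phenyl group alone. This last step rests on a limit of the assay and not on a number: the limit of > 15800 nM in this assay, at which 1 of the 3 values shown sits.

The compounds shown leave open how an unsubstituted phenyl, or a phenyl carrying a morpholine in place of the dimethylamino group, would read in this assay. They also leave open whether either of the two groups that give a number would keep its standing with a change elsewhere on the shared core.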